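A few compounds are considered here, and "the series" means these few. Any claim that something is new, unique, unknown or untested is made for them only; others in the source may bear on it.

Compound 1, with the structure `COC(=O)C1=C(C)N=C(C)/C(=C(\O)OC)C1c1cc([N+](=O)[O-])ccc1O`, is measured in a functional assay (muscle tissue) with Cavia porcellus as the target (a lower number here means that less compound is needed, a higher number that more compound is needed for the effect), where compound 1 gives 100 nM. Two further compounds share its core. Compound 2, with the structure `COC(=O)C1=C(C)N=C(C)/C(=C(\O)OC)C1c1cc(Cl)cc(Cl)c1`, gives 93.3 nM in this assay, a number that lies within the scatter of compound 1. Compound 3, with the structure `COC(=O)C1=C(C)N=C(C)/C(=C(\O)OC)C1c1cccc(N(C)C)c1`, gives 891 nM in this assay, a number that lies beyond the scatter from compound 1. Compound 1 thus stands second highest among the three, close to compound 2 and far from compound 3.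

Compound 4, with the structure `COC(=O)C1=C(C)N=C(C)/C(=C(\O)OC)C1c1cc([N+](=O)[O-])ccc1Cl`, has not yet been measured. It differs from compound 1 in one place: chloro in place of hydroxy on an aromatic carbon. For the measured compounds named here, no step between measured compounds tells what such a change does here. Compound 4 is expected to sit near compound 1 because compound 2 with chloro groups on its aryl ring gives 93.3 nM in this assay. The expected step in this assay is a 1.1-fold lower number from compound 1 to compound 4 (0.05 log units; within the scatter), a change not beyond the scatter. Compound 4 is therefore estimated at 90 nM in this assay, with a range from 30 nM to 300 nM.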

Compound 4, half-maximal effective concentration: 30.2 nM
The estimate for compound 4 lay 3.0-fold (0.47 log units) above the measured number; the measured number falls inside the stated range.
By their numbers in this assay, from the lowest: compound 4; then compounds 2 and 1 (each within the scatter of the next); then compound 3.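

In this assay, chloro in place of hydroxy on the aromatic carbon ortho to a large group and para to a nitro group gives a 3.3-fold lower number from compound 1 to compound 4 (0.52 log units; beyond the scatter), so less compound is needed for the effect with chloro at this position. For the compounds shown here, as the only step here that isolates a single change, it shows that this position responds to its substituent and that the hydroxy group, with its hydrogen-bond donor, is not needed for the effect. Nothing available here bears on why the number moves.

The compounds shown leave open whether fluoro, methoxy or methyl on the same carbon would act as chloro does, or an amine as hydroxy does. They also leave open whether the step would hold with a nitrile in place of the nitro group.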